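Hydroxy-to-(methylsulfanyl)methoxy step on a dichloroaryl formamidine series

This account rests on a few compounds, and the source may have more. Where it says the series, first, only, none or still open, it means among the compounds named here.

Measured so far in a physicochemical assay for lipophilicity, measured as octanol-water partition; on this read-out higher numbers stand for higher lipophilicity and lower numbers for lower lipophilicity:
Compound 1, `C=CCOc1c(Cl)cc(N/C=N/OCC)cc1Cl`: compound 1 gives 4.3.
Compound 2, `CCO/N=C/Nc1cc(Cl)c(OCCCl)c(Cl)c1`: compound 2 gives 4.
Compound 3, `C#CCc1c(Cl)cc(N/C=N/O)cc1Cl`: compound 3 gives 2.8.

Compound 3 stands lowest of the three values, beyond the scatter from both compound 1 and compound 2. Compound 4, `C#CCc1c(Cl)cc(N/C=N/OCSC)cc1Cl`, differs from compound 3 in one place: (methylsulfanyl)methyl in place of hydrogen on an oxygen. Within the data shown here, the only step measured so far, a number 0.30 log units lower from compound 1 to compound 2 (within the scatter), concerns a different part of the molecule and does not bear on the oxygen in question; compound 1 and compound 2 differ from compound 3 in more than one place, so only their values can be compared. The change adds three heavy atoms without a donor, so an upward step is expected for compound 4 in this assay, a number 1.00 log units higher from compound 3 to compound 4 (beyond the scatter). Compound 4 is estimated at 3.8, in the range 3.2 to 4.4.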

Compound 4, partition coefficient: 3.6
Beside the measured number, compound 4's estimate is 0.20 log units above it; the measured number falls inside the stated range.
By their numbers in this assay, from the lowest: compound 3; then compound 4; then compounds 2 and 1 (each within the scatter of the next).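

In this assay, among these compounds, hydroxy to (methylsulfanyl)methoxy on the oxygen whose other neighbour is the double-bonded nitrogen gives the first one-place step at this position: a number 0.80 log units higher from compound 3 to compound 4 (beyond the scatter). The earlier step concerned a different part of the molecule, so this reading is the only direct measure of a change on this oxygen.

Open, from the compounds shown here alone, is how methyl, methoxymethyl or a longer alkyl chain on this oxygen would compare, which would separate the contribution of the sulfur from that of the chain. No measurement at hand accounts for the size of this step.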